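Replacing the methoxyethyl side chain with a triazolyl-ethyl group

The source may hold more compounds than are shown below. What is called first, only, known or untested is meant among the compounds shown, and "the series" means these compounds.

Measured compounds:
compound 1 `CN(C)CCC(=O)Nc1ccc([C@H]2[C@@H](F)[C@@H](F)C[C@@H](F)[C@H]2F)cc1`: 3.7 10^-6 cm/s
compound 2 `N#CCC(=O)Nc1ccc([C@H]2[C@@H](F)[C@@H](F)C[C@@H](F)[C@H]2F)cc1`: 16 10^-6 cm/s
compound 3 `COCCC(=O)Nc1ccc([C@H]2[C@@H](F)[C@@H](F)C[C@@H](F)[C@H]2F)cc1`: 18.1 10^-6 cm/s

All three share one core and differ only in the chain on the carbonyl carbon of the amide. In an ADME assay on MDCK-MDR1 cells (Canis lupus familiaris) for permeability, in the apical to basolateral direction, with a stated time of 180 min (a higher number here means that the compound crosses the layer faster, a lower number that the compound crosses the layer more slowly), compound 3 gives the highest number of the three; its gap to compound 2 is within the scatter, while a 4.9-fold higher number from compound 1 to compound 3 (0.69 log units; beyond the scatter) is a clear step. Compound 4 `CC(C(=O)Nc1ccc([C@H]2[C@@H](F)[C@@H](F)C[C@@H](F)[C@H]2F)cc1)n1cncn1` is not yet measured. The change from compound 3 is 1-(1H-1,2,4-triazol-1-yl)ethyl in place of 2-methoxyethyl on a carbonyl carbon. The entering group carries no net charge, like the groups in compound 2 and compound 3, whose numbers sit close together; only the dimethylamino group of compound 1 stood apart. A step of a 1.8-fold lower number from compound 3 to compound 4 (0.26 log units; within the scatter) is therefore expected, modest and downward. For compound 4 the estimate is 10 10^-6 cm/s, within 4 10^-6 cm/s to 22 10^-6 cm/s.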

Compound 4, apparent permeability: 5.5 10^-6 cm/s
Compound 4: the middle estimate sits 1.8-fold (0.26 log units) above what was measured; measured number inside the range.
By their numbers in this assay, from the lowest: compounds 1 and 4 (each within the scatter of the next); then compounds 2 and 3 (each within the scatter of the next).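

Carrying no net charge is not enough to keep the number high at this carbonyl carbon: 1-(1H-1,2,4-triazol-1-yl)ethyl gives a 3.3-fold lower number from compound 3 to compound 4 (0.52 log units; beyond the scatter) and a 2.9-fold lower number from compound 2 to compound 4 (0.46 log units; beyond the scatter). With a 1.5-fold higher number from compound 1 to compound 4 (0.17 log units; within the scatter), it stands level with the 2-(dimethylamino)ethyl chain, so two very different groups now share the low end. No measurement shown here explains these steps.

The change brings in a ring and a branched chain together, so the compounds shown cannot say which of the two goes with the lower number. An unbranched triazolylethyl chain or a pyrazole ring at this carbon would help separate them.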